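The source may report more compounds than this note shows. Statements on the series, on what has been measured and on what is new or still open speak of the compounds shown alone.

Measured so far:
Compound 1 `Cc1ccc(NCc2cn(-c3ccccc3)nc2-c2ccc(C(F)(F)F)cc2)cc1`: 82000 nM
Compound 2 `FC(F)(F)c1ccc(NCc2cn(-c3ccccc3)nc2-c2ccc(Br)cc2)cc1`: 28000 nM
Compound 3 `Cc1ccc(-c2nn(-c3ccccc3)cc2CNc2ccc(Br)cc2)cc1`: 92000 nM

These numbers come from an ADME assay on Vero 76 cells (Chlorocebus sabaeus) for cytotoxicity, read by MTT assay, with a stated time of 96 h; a higher number here means that more compound is tolerated, a lower number that less compound is tolerated. Compound 2 stands lowest of the three, and the gaps up to compound 1 and compound 3 both lie beyond the usual scatter. Compound 4 `FC(F)(F)c1ccc(NCc2cn(-c3ccccc3)nc2-c2ccccc2)cc1` is not yet measured. It differs from compound 2 by one change, hydrogen in place of bromo on an aromatic carbon. Among the measured compounds shown here, no two measured compounds differ in just one place, so the data show no direct precedent for this step. With compound 3 at 92000 nM and compound 1 at 82000 nM, there is room above compound 2, and a modest rise is expected, an estimated step of a 2.3-fold higher number from compound 2 to compound 4 (0.37 log units; beyond the scatter). For compound 4 the expected value is 65000 nM, with an estimated range of 28000 nM to 100000 nM.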

Compound 4, half-maximal cytotoxic concentration: 17000 nM
The estimate for compound 4 lay 3.8-fold (0.58 log units) above the measured number, and the stated range ends above it.
By their numbers in this assay, from the lowest: compounds 4 and 2 (each within the scatter of the next); then compounds 1 and 3 (each within the scatter of the next).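

In this assay, among the compounds shown here, replacing the 4-bromophenyl group with phenyl gives a 1.6-fold lower number from compound 2 to compound 4 (0.22 log units; within the scatter) and is the first one-place comparison in this set. This pair therefore gives no sign that the bromo at this position sets how much compound the cells tolerate, although a single pair cannot establish a general rule. No measurement available here offers any explanation for this result.

Still open, as far as these compounds go, is whether a methoxy group, an amine or a carboxylic acid at this position would move the number beyond the scatter. Also open, from the compounds shown here alone, is whether the same replacement would read alike on a different core.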